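Aromatic tail variation in a guanidine series of histamine agonists

The source may report more compounds than this note shows. Statements on the series, on what has been measured and on what is new or still open speak of the compounds shown alone.

Measured so far, with a functional assay on Right cardiac atrium for agonist activity at histamine H2 receptor (Cavia porcellus), with a stated time of 30 min, in the presence of a further agent that is not named here (a lower number here means a smaller maximal response, a higher number a larger maximal response), as the read-out:
Compound 1, `Cc1nc(N)sc1CCCN/C(N)=N/C(=O)NC(C)c1ccc(Br)cc1`, gives 0.87.
Compound 2, `Cc1ccc(C(C)NC(=O)/N=C(\N)NCCCc2sc(N)nc2C)cc1`, gives 0.85.
Compound 3, `Cc1nc(N)sc1CCCN/C(N)=N/C(=O)NC(C)c1cccs1`, gives 0.88.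

Compound 3 holds the highest of the three numbers, yet a number 0.010 higher from compound 1 to compound 3 (within the scatter) and a number 0.030 higher from compound 2 to compound 3 (within the scatter) both sit within the scatter, so no order among the three can be claimed. Compound 4, `Cc1nc(N)sc1CCCN/C(N)=N/C(=O)NC(C)c1ccco1`, differs from compound 3 only in the tail: furan-2-yl in place of thiophen-2-yl on a saturated chain carbon bound to an amide-type nitrogen and a saturated chain carbon.

The bearing steps are the earlier swaps at this same place, a number 0.010 higher from compound 1 to compound 3 (within the scatter) and a number 0.030 higher from compound 2 to compound 3 (within the scatter), each small. On that basis no step beyond the scatter is expected for compound 4 in this assay: a number 0.020 lower from compound 3 to compound 4 (within the scatter). Compound 4 is estimated at 0.86, within 0.78 to 0.94.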

Compound 4, intrinsic activity: the largest response reached, as a fraction of the reference agonist's: 1
For compound 4 the middle estimate is 0.14 below the measured one; measured number above the stated range.
By their numbers in this assay, from the lowest: compounds 2, 1 and 3 (each within the scatter of the next); then compound 4.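

In this assay this position proves able to shift the maximal response, with furan-2-yl separating from all three earlier tails: a number 0.12 higher from compound 3 to compound 4 (beyond the scatter), a number 0.15 higher from compound 2 to compound 4 (beyond the scatter) and a number 0.13 higher from compound 1 to compound 4 (beyond the scatter). Oxygen in place of sulfur in the five-membered aromatic ring, at an unchanged heavy-atom count, is enough for this, while the swaps among the earlier tails all stayed within the scatter. Nothing available accounts for the difference.

On these data alone, whether a 5-methylfuran-2-yl or a pyridin-2-yl group at this place gives a similar response remains open. So does whether the furan-2-yl step holds with a longer chain in the core.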